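The compounds below may be only part of what the source reports. "The series", "measured", "known", "first", "only" and "open" are said of these compounds alone.

Measured compounds:
- compound 1, `O=S(=O)(Nc1ccc(CNc2nc(NC3CC3)nc3ccccc23)cc1)c1ccc(F)cc1`: in a functional assay on SW480 cells (Homo sapiens) for inhibition, read by luminescence and resazurin assay, with a stated time of 3 days (a higher number here means a weaker inhibitor, a lower number a stronger inhibitor), compound 1 gives 4100 nM
- compound 2, `CCNc1nc(NCc2ccc(C(=O)Nc3ccc(F)cc3)cc2)c2ccccc2n1`: in this assay compound 2 gives 2500 nM

Compound 2 holds the lower of the two numbers recorded so far in this assay, but its nearest neighbour, compound 1, sits within the usual scatter of it, so the two cannot be told apart on these figures. The two compounds also differ from each other in more than one place, and no single-point comparison between them is available.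

Compound 3, `O=C(Nc1ccc(F)cc1)c1ccc(CNc2nc(NC3CC3)nc3ccccc23)cc1`, shares the amide-bearing side chain of compound 2 and differs from it in one place only: cyclopropyl in place of ethyl on a nitrogen on an aromatic ring. Going by the values given here, the same exchange has not been measured on any pair of compounds in this set, so there is no measured step to lean on. A change of this size, one carbon added on the nitrogen on the aromatic ring and the chain closed into a three-membered ring, is expected to move the number in this assay little, if at all, beyond the scatter, in either direction. The step expected from compound 2 to compound 3 in this assay is therefore a 1.1-fold lower number from compound 2 to compound 3 (0.06 log units; within the scatter). Compound 3 is accordingly estimated at 2200 nM in this assay, with a range from 800 nM to 6000 nM.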

Compound 3, half-maximal inhibitory concentration: 2600 nM
The estimate for compound 3 lay 1.2-fold (0.07 log units) below the measured number, within the range that was stated.
By their numbers in this assay, from the lowest: compounds 2, 3 and 1 (each within the scatter of the next).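

With the rest of the structure held, cyclopropyl in place of ethyl on a nitrogen on an aromatic ring gives a 1.0-fold higher number from compound 2 to compound 3 (0.02 log units; within the scatter) in this assay, so at this position the ethylamino to cyclopropylamino exchange cannot be told from no change at all. Going by these compounds alone, compound 3 also provides the first single-place comparison with compound 1: (4-fluorophenyl)carbamoyl in place of ((4-fluorophenyl)sulfonyl)amino on an aromatic carbon gives a 1.6-fold lower number from compound 1 to compound 3 (0.20 log units; within the scatter), so this exchange likewise cannot be read as a change, and the three compounds stand as one group on these figures. No measurement at hand offers an explanation for either result.

The compounds shown leave open whether a longer chain on that nitrogen, or a carboxylic acid in place of the (4-fluorophenyl)carbamoyl, would move the number beyond the scatter. They also leave open whether the exchange of ethyl for cyclopropyl would read the same with ((4-fluorophenyl)sulfonyl)amino in the side chain, as each of the two steps rests on a single pair of compounds.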